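Chloro for Methyl: Expected Plasma Activity of Compound 3

This account rests on a few compounds, and the source may have more. Where it says the series, first, only, none or still open, it means among the compounds named here.

Of the compounds shown here, two have so far been measured in a functional assay on the whole organism (plasma, strain Wistar) with Rattus norvegicus as the target, with a stated time of 15 days, at a dose of 10 mg/kg by the oral route; a lower number here means a weaker effect, a higher number a stronger effect of the compound at the dose given. Compound 1 `Cc1nc(COc2ccc(/C=C3\SC(=O)NC3=O)cc2)cs1` gives 10.6% there, and compound 2 `Cc1ccc(-c2nnc(SCCOc3ccc(/C=C4\SC(=O)NC4=O)cc3)[nH]2)cc1` gives 20.4%. Within the data shown here, compound 2 holds the higher of the two numbers, yet its only neighbour, compound 1, lies within the usual scatter of such measurements, so the two cannot be told apart. Compound 3 `O=C1NC(=O)/C(=C/c2ccc(OCCSc3nnc(-c4ccc(Cl)cc4)[nH]3)cc2)S1` has not yet been tested. Relative to compound 2 it carries a single change, (chloro in place of methyl on an aromatic carbon); seen one bond further out, a 4-methylphenyl becomes a 4-chlorophenyl. Among the measured compounds shown here, no measured pair shows this exchange, so the data give no size for its effect. The expected step is small, a number 1.4 percentage points lower from compound 2 to compound 3 (within the scatter), with no direction beyond the scatter. Compound 3 is therefore estimated at 19% in this assay, with a range from 8% to 34%.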

Compound 3, a percentage reported as activity, at one dose (the size of the read-out at that dose, not a potency): 19.6%
The estimate for compound 3 lay 0.6 percentage points below the measured number; the range from low to high includes it.
By their numbers in this assay, from the lowest: compounds 1, 3 and 2 (each within the scatter of the next).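

In this assay, the exchange of a 4-methylphenyl for a 4-chlorophenyl now has a measured size, a number 0.8 percentage points lower from compound 2 to compound 3 (within the scatter). Compound 1 and compound 2 differ in more than one place and could say nothing about a single change, whereas this pair shows that methyl and chloro, on an aromatic carbon para to a large group, cannot be told apart by this read-out. Nothing measured here explains this outcome.

Whether an amine, a carboxylic acid or a methoxy group in that same place would carry the number beyond the scatter remains open; methyl and chloro are the only groups shown there. Also open is how a longer chain between the shared core and the aromatic end would read, for no pair shown isolates that part.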